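The source may report more compounds than this note shows. Statements on the series, on what has been measured and on what is new or still open speak of the compounds shown alone.

Compound 1 `CC1(C)S[C@@H]2/C(=C\C(=O)c3cc(C(F)(F)F)cc(C(F)(F)F)c3)C(=O)N2[C@H]1C(=O)OC(c1ccccc1)c1ccccc1`, compound 2 `CC1(C)S[C@@H]2/C(=C\C(=O)c3ccc(Cl)cc3)C(=O)N2[C@H]1C(=O)OC(c1ccccc1)c1ccccc1` and compound 3 `CC1(C)S[C@@H]2/C(=C\C(=O)OC(c3ccccc3)c3ccccc3)C(=O)N2[C@H]1C(=O)OC(c1ccccc1)c1ccccc1` were tested in a functional assay on OE19 cells (Homo sapiens) for cytotoxicity, read by MTT assay, with a stated time of 48 h; a higher number here means a weaker inhibitor, a lower number a stronger inhibitor. Compound 1 gives 48500 nM, compound 2 gives 14600 nM and compound 3 gives 21600 nM. Compound 2 holds the lowest of the three numbers; its gap to compound 3 lies within the scatter, whereas its gap to compound 1 lies beyond it. Compound 4 `CC1(C)S[C@@H]2/C(=C\C(=O)c3ccc4ccccc4c3)C(=O)N2[C@H]1C(=O)OC(c1ccccc1)c1ccccc1` carries naphthalen-2-yl in place of 4-chlorophenyl on a carbonyl carbon. Among the compounds with values here, no step between two measured compounds is available to gauge this change, and the three measured values span only a modest range. The step of a 1.1-fold lower number from compound 2 to compound 4 (0.05 log units; within the scatter) is therefore expected to be small, in either direction, and not clearly beyond the scatter. Compound 4 is estimated to give 13000 nM, within a range from 5000 nM to 35000 nM.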

Compound 4, half-maximal inhibitory concentration: 19500 nM
Estimate against measurement, compound 4: 1.5-fold (0.18 log units) below; measured number inside the range.
By their numbers in this assay, from the lowest: compounds 2, 4 and 3 (each within the scatter of the next); then compound 1.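

Naphthalen-2-yl in place of 4-chlorophenyl on a carbonyl carbon gives the step of a 1.3-fold higher number from compound 2 to compound 4 (0.13 log units; within the scatter) in this assay and is the first change at this position that can be read as a single step. Adding a second six-membered aromatic ring and removing the chlorine thus leave the number within the scatter here. No measured property of these groups bears on this result. As far as these compounds go, it remains open whether an amine or a carboxylic acid in place of the aromatic group on this carbonyl carbon would keep the number in this range. Also open, from the compounds shown here alone, is whether plain phenyl would read like compound 2 and compound 4.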